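Furan to thiophene on the amide carbonyl

The compounds below may be only part of what the source reports. "The series", "measured", "known", "first", "only" and "open" are said of these compounds alone.

Compound 1 `Cc1ccc(C(=O)N2CCCC2c2nnn(-c3cccc(Cl)c3)n2)o1` has the higher of the two numbers recorded in an assay on cell membranes for displacement of a labelled ligand from metabotropic glutamate receptor 5 (Rattus norvegicus); on this read-out higher numbers stand for weaker inhibition and lower numbers for stronger inhibition: compound 1 gives 105 nM, while compound 2 `O=C(c1ccc(Br)o1)N1CCCCC1c1nnn(-c2cccc(Cl)c2)n1` gives 49 nM, a lower number that lies beyond the scatter. On these data alone, compound 3 `Cc1ccc(C(=O)N2CCCC2c2nnn(-c3cccc(Cl)c3)n2)s1` is untested; it differs from compound 1 by 5-methylthiophen-2-yl in place of 5-methylfuran-2-yl on a carbonyl carbon. Going by the values given here, no measured pair isolates this change, so only a small step is expected, if anything toward a lower number, and likely within the scatter. Compound 3 is therefore estimated at 80 nM, with a range from 30 nM to 200 nM. This corresponds to an expected step of a 1.3-fold lower number from compound 1 to compound 3 (0.12 log units; within the scatter).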

Compound 3, inhibition constant: 89.1 nM
The estimate for compound 3 lay 1.1-fold (0.05 log units) below the measured number; the range from low to high includes it.
By their numbers in this assay, from the lowest: compounds 2, 3 and 1 (each within the scatter of the next, the first and the last beyond it).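

Sulfur in place of oxygen in the five-membered aromatic ring gives a 1.2-fold lower number from compound 1 to compound 3 (0.07 log units; within the scatter) in this assay. This position therefore accepts sulfur for oxygen in the five-membered aromatic ring with no shift beyond the scatter. No measured property bears on this result.

Compound 2 differs from compound 1 in more than one place, so the contribution of each of its changes remains unresolved. Also open, on these data alone, is how a phenyl or pyridin-2-yl group on the same carbonyl carbon would read.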